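Working notes: methoxy in place of trifluoromethyl

The source may hold more compounds than are shown below. What is called first, only, known or untested is meant among the compounds shown, and "the series" means these compounds.

Read-outs so far in a functional assay on SF-268 cells (Homo sapiens) for inhibition, with a stated time of 48 h (on this read-out higher numbers stand for weaker inhibition of growth and lower numbers for stronger inhibition of growth), are few.
- Compound 1 `COC(=O)CNC(=O)c1ccc(-n2ncc3c(N)ncnc32)cc1` gives > 150000 nM (a limit)
- Compound 2 `Cc1ccc(-n2ncc3c(N)ncnc32)cc1` gives "not determined" (no result reported) (no number)
- Compound 3 `Nc1ncnc2c1cnn2-c1ccc(C(F)(F)F)cc1` gives "not determined" (no result reported) (no number)

Compound 3 therefore has no place on the scale of this read-out. Compound 2 offers no number to compare it with either. The one entry with any numerical content is compound 1, which stands at the limit of > 150000 nM in this assay, at which 1 of the 3 values shown sits, and is a limit, not a number.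

Compound 4 `COc1ccc(-n2ncc3c(N)ncnc32)cc1` is the next to be read. The change methoxy in place of trifluoromethyl on an aromatic carbon puts methoxy in place of trifluoromethyl on an aromatic carbon, para to a large group.

Among the measured compounds shown here, no measured step gives a size for this change. A step beyond the scatter is not expected in this assay and no direction is assigned, the sole reference being the limit of compound 1 at > 150000 nM in the same read-out.

Compound 4 is estimated at 150000 nM with an expected range from 50000 nM to 400000 nM and may well come out only as a limit.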

Compound 4, concentration for 50% growth inhibition: > 150000 nM
Compound 4 ended at the assay's limit; the forecaster's own chance of this, stated with the estimate: 65%; the middle value lies on the limit itself.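

No step can be read between compound 1 and compound 4 in this assay, as each entry is a limit and not a number: the limit of > 150000 nM in this assay, at which 2 of the 4 values shown sit.

The compounds shown leave open whether any group on the shared core, methoxy included, changes growth inhibition in this assay.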